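Moving the amino group on the weak stilbene-type series

The source may hold more compounds than are shown below. What is called first, only, known or untested is meant among the compounds shown, and "the series" means these compounds.

In a functional assay on HL-60 cells (Homo sapiens), with a stated time of 48 h (a higher number here means that more compound is needed for the effect, a lower number that less compound is needed), compound 1 `COc1ccc(/C=C\c2ccc3c(c2)C(C)(C)CCC3(C)C)cc1N` gives 87000 nM, so a high concentration is needed for the effect. Compound 2 `CC1(C)CCC(C)(C)c2cc(/C=C\c3ccc(N)cc3)ccc21` reads > 100000 nM in this assay, which is a limit of the assay and not a number. Among the measured compounds shown here, no measured pair isolates a single change, so neither compound offers a step to carry forward, and the two readings sit close to the limit of > 100000 nM in this assay, at which 1 of the 2 values shown sits.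

Compound 3 `CC1(C)CCC(C)(C)c2cc(/C=C\c3cccc(N)c3)ccc21` has the same atoms as compound 2, joined differently. It carries 3-aminophenyl in place of 4-aminophenyl on a double-bonded chain carbon bound to a double-bonded chain carbon.

For the measured compounds named here, the only number to lean on is compound 1 at 87000 nM, which gives no reason to expect a large gain. The expected change is small and no clear move beyond the scatter is foreseen, with the estimate for an at least 1.1-fold lower number from compound 2 to compound 3 (0.04 log units; that floor lies within the scatter) leaning only slightly towards less compound being needed. A result reported again only as a limit would not be surprising. For compound 3 the estimated value is 90000 nM, with an expected range of 25000 nM to 200000 nM.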

Compound 3, concentration for half-maximal activity: 25000 nM
Estimate against measurement, compound 3: 3.6-fold (0.56 log units) above; the measured number falls inside the stated range.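

Moving the amino group, with 3-aminophenyl in place of 4-aminophenyl on a double-bonded chain carbon bound to a double-bonded chain carbon, gives in this assay an at least 4.0-fold lower number from compound 2 to compound 3 (0.60 log units; beyond the scatter), the first single change in the series with a readable step, and it lies beyond the scatter. The size of that step is only a floor, as compound 2 is recorded at a limit of the assay and not at a number: the limit of > 100000 nM in this assay, at which 1 of the 3 values shown sits. Hydrogen in place of methoxy on an aromatic carbon gives a 3.5-fold lower number from compound 1 to compound 3 (0.54 log units; beyond the scatter), so the methoxy group is not required for the effect once the 3-aminophenyl group is present, though compound 3 at 25000 nM still needs a high concentration.

The compounds shown leave open whether the gain belongs to the amino group itself or would also appear with a hydroxyl group, a carboxylic acid or an acetamide at the same place. Also open, going by these compounds, is whether the change carries over to a compound in which the shared core is altered.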